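This account rests on a few compounds, and the source may have more. Where it says the series, first, only, none or still open, it means among the compounds named here.

The series shares one core, seen in compound 1 `CC(C)c1ccccc1-c1nc(NCc2ccc(-c3cccnc3)cc2)c2occc2n1`, in compound 2 `CC(C)c1ccccc1-c1ncc(N(C)C)c(NCc2ccc(-c3cccnc3)cc2)n1` and in compound 3 `Cc1cnc(-c2ccccc2C(C)C)nc1NCc1ccc(-c2ccc(F)nc2)cc1`, each carrying a biaryl-substituted benzylamine. In an assay on a protein complex for inhibition of ubiquitin carboxyl-terminal hydrolase 1/WD repeat-containing protein 48 (Homo sapiens), read by fluorescence (on this read-out higher numbers stand for weaker inhibition and lower numbers for stronger inhibition), compound 1 gives 80 nM, and compound 2 gives 190 nM. Compound 3 gives 80 nM in this assay. Compound 3 thus stands level with compound 1 at the digits shown, the two together at the low end of the three numbers, while compound 2 sits at a number that is higher by a margin beyond the usual scatter.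

The unmeasured compound 4 `Cc1cnc(-c2ccccc2C(C)C)nc1NCc1ccc(-c2nnn[nH]2)cc1` differs from compound 3 in one place: 1H-tetrazol-5-yl in place of 6-fluoropyridin-3-yl on an aromatic carbon. Among the compounds with values here, no pair among the measured compounds shows this kind of exchange, so the data give no direct guide to its effect. The exchange removes the six-membered aromatic ring with one hetero atom and brings in a five-membered aromatic ring with four hetero atoms and one hydrogen-bond donor, a considerable change at this position. It is expected to cost some inhibition in this assay, a step of a 3.8-fold higher number from compound 3 to compound 4 (0.57 log units; beyond the scatter), though the uncertainty is wide in both directions. Compound 4 is therefore estimated at 300 nM, within a range from 80 nM to 1500 nM.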

Compound 4, half-maximal inhibitory concentration: 5900 nM
Estimate against measurement, compound 4: 20-fold (1.29 log units) below; measured number above the stated range.
By their numbers in this assay, from the lowest: compounds 1 and 3 (each within the scatter of the next); then compound 2; then compound 4.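

At this position, on an aromatic carbon of a six-membered aromatic ring of carbon only and para to a large group, putting 1H-tetrazol-5-yl in place of 6-fluoropyridin-3-yl gives in this assay a 74-fold higher number from compound 3 to compound 4 (1.87 log units; beyond the scatter), a large loss of inhibition and well beyond the scatter. Within the data shown here, this is the first exchange at this place that can be read directly, and it shows that the position is far from indifferent to what it carries: with the rest of compound 3 unchanged, this one exchange is enough to take compound 4 to the highest number of the four. The compounds shown offer no independent evidence on why the step is so large, and its cause remains unestablished.

The exchange changes ring size, the number of hetero atoms and the hydrogen-bond donor count all at once, so the pair cannot say which of these differences matters. On these data alone, how a phenyl ring, a carboxylic acid or a methyl-substituted tetrazole would fare at this place, and so where between these two results such groups would fall, remains open.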